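Series notes: benzyl to benzoylmethyl on the sulfur chain

This account rests on a few compounds, and the source may have more. Where it says the series, first, only, none or still open, it means among the compounds named here.

In a functional assay on HepG2 cells (Homo sapiens) for cytotoxicity, read by MTT assay, with a stated time of 48 h (a higher number here means a weaker inhibitor, a lower number a stronger inhibitor), compound 1 `CCc1nnc(SCc2ccccc2)n1N1C(=O)c2ccccc2C1=O` gives > 200000 nM, which is a limit of the assay and not a number. Compound 2 `CCCc1nnc(SCc2ccccc2)n1N1C(=O)c2ccccc2C1=O` gives > 200000 nM in this assay, again only a limit. The step that the two limits leave unreadable from compound 1 to compound 2 is consequently unreadable. Compound 2 thus stands at a limit, as does every value obtained so far (the limit of > 200000 nM in this assay, at which 2 of the 2 values shown sit). Compound 3 `CCCc1nnc(SCC(=O)c2ccccc2)n1N1C(=O)c2ccccc2C1=O` differs from compound 2 by benzoyl in place of phenyl on a saturated chain carbon bound to a sulfur. Going by the values given here, no measured step bears on this change: the only step measured is unreadable, and neither measured compound reaches a number in this assay. No step beyond the scatter is therefore expected in this assay. The expected step is a step that the limit leaves unreadable from compound 2 to compound 3. Compound 3 is estimated at 250000 nM, in the range 60000 nM to 1000000 nM, and is most likely again reported only as a limit.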

Compound 3, half-maximal inhibitory concentration: > 200000 nM
Compound 3: no number, only a limit; the forecaster's own chance of this, stated with the estimate: 70%; the middle value does not contradict the limit.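

No new step can be read between compound 2 and compound 3, because both stand only at a limit: the limit of > 200000 nM in this assay, at which 3 of the 3 values shown sit.
Whether benzoyl in place of phenyl changes anything in this assay stays open, as does what any compound shown would give as a number.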